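The compounds below may be only part of what the source reports. "The series", "measured", "known", "first", "only" and "open" are said of these compounds alone.

Compound 1 `CN1CCN(C2=Nc3ccccc3CC=C2c2ccc(F)cc2)CC1` gives 43.3% in a functional assay on the whole organism with Mus musculus as the target, at a dose of 10 mg/kg by the oral route; on this read-out higher numbers stand for a stronger effect at the one dose given and lower numbers for a weaker effect.
Compound 2 `CCN1CCN(C2=Nc3ccccc3CC=C2c2ccc(F)cc2)CC1` gives 10.6%.

Among the measured compounds shown here, on these two numbers compound 2 stands lowest; the only other compound, compound 1, sits higher by a margin beyond the scatter. Compound 3 `CCCN1CCN(C2=Nc3ccccc3CC=C2c2ccc(F)cc2)CC1` carries the change (methyl in place of hydrogen on a saturated chain carbon, two bonds along the chain from an amine nitrogen in a ring). For the measured compounds named here, the one measured step that bears on it is a number 32.7 percentage points lower from compound 1 to compound 2 (beyond the scatter), a change of the same kind, methyl to ethyl, which lowered the read-out by a large amount. A fall in the same direction is therefore expected, though compound 2 already sits near the floor of the scale, so the expected step of a number 5.6 percentage points lower from compound 2 to compound 3 (within the scatter) is a small further drop. Compound 3 is estimated at 5%, with a range from -10% to 25%.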

Compound 3, a percentage reported as inhibition, in the whole organism at one dose (the size of the read-out at that dose, not a potency): 18.5%
For compound 3 the middle estimate is 13.5 percentage points below the measured one, within the range that was stated.
By their numbers in this assay, from the lowest: compounds 2 and 3 (each within the scatter of the next); then compound 1.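

In this assay the change from ethyl to propyl gives a number 7.9 percentage points higher from compound 2 to compound 3 (within the scatter) and so does not separate the two compounds, unlike the earlier change from methyl to ethyl. Taken together, the change from methyl to propyl still amounts to a number 24.8 percentage points lower from compound 1 to compound 3 (beyond the scatter) and leaves methyl with the largest read-out of these three compounds. No measurement given here explains this behaviour.

On these data alone, whether a longer chain such as butyl would stay at the level of ethyl and propyl remains open. So does the effect of a hydrogen or a 2-hydroxyethyl group in place of methyl.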